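Aryl ester in place of acetate on the tetraol core

The source may report more compounds than this note shows. Statements on the series, on what has been measured and on what is new or still open speak of the compounds shown alone.

In a functional assay on MDA-MB-231 cells (Homo sapiens) for antiproliferative activity, read by MTT assay, with a stated time of 72 h (on this read-out higher numbers stand for weaker inhibition and lower numbers for stronger inhibition), compound 1 `CC(=O)O[C@H]1CC[C@]2(C)[C@H](CC[C@@](C)(O)[C@H]2CC[C@@H]2C(C)=CC[C@H]3[C@H](CC[C@]3(C)O)C2(C)C)OC1(C)C` gives 38000 nM, the second highest of the three numbers. Compound 2 `CC(=O)O[C@H]1CC[C@]2(C)[C@H](CC[C@@](C)(O)[C@H]2CC[C@@H]2C(C)=CC[C@@H]3C(C)=CC[C@@H]3C2(C)C)OC1(C)C` gives 39200 nM, within the scatter of compound 1. Compound 3 `CC1=CC[C@H]2[C@@H]1CC=C(C)[C@@H](CC[C@H]1[C@]3(C)CC[C@H](OC(=O)c4ccc(Cl)cc4)C(C)(C)O[C@H]3CC[C@@]1(C)O)C2(C)C` gives 12700 nM. Among the compounds with values here, the only step known, a 3.1-fold lower number from compound 2 to compound 3 (0.49 log units; beyond the scatter), exchanges the acetate for a 4-chlorophenyl ester on the unsaturated core. Compound 4 `CC1=CC[C@H]2[C@H](CC[C@]2(C)O)C(C)(C)[C@@H]1CC[C@H]1[C@]2(C)CC[C@H](OC(=O)c3ccc(C(F)(F)F)cc3)C(C)(C)O[C@H]2CC[C@@]1(C)O` applies a related exchange to compound 1: 4-(trifluoromethyl)phenyl in place of methyl on a carbonyl carbon, acetyl to (4-(trifluoromethyl)phenyl)carbonyl. Within the data shown here, the one bearing step is modest but beyond the scatter, so a lowering of similar size is expected in this assay. The expected step is a 2.9-fold lower number from compound 1 to compound 4 (0.47 log units; beyond the scatter). Among the measured compounds shown here, compound 4 is therefore estimated at 13000 nM, with a range from 5500 nM to 32000 nM; the single precedent leaves the size of the step uncertain.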

Compound 4, half-maximal inhibitory concentration: 19500 nM
The estimate for compound 4 lay 1.5-fold (0.18 log units) below the measured number, within the range that was stated.
By their numbers in this assay, from the lowest: compounds 3, 4, 1 and 2 (each within the scatter of the next, the first and the last beyond it).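

On the core of compound 1, 4-(trifluoromethyl)phenyl in place of methyl on a carbonyl carbon gives a 1.9-fold lower number from compound 1 to compound 4 (0.29 log units; within the scatter) in this assay. This position therefore accepts this aryl ester, but the exchange is not resolved from the acetate, unlike a 3.1-fold lower number from compound 2 to compound 3 (0.49 log units; beyond the scatter). No evidence on the cause accompanies these numbers.

The 4-chlorophenyl and 4-(trifluoromethyl)phenyl esters stand on different cores, so the contributions of aryl group and core cannot be separated. Going by these compounds, how an unsubstituted phenyl ester or a longer alkyl chain on the carbonyl carbon would read remains open.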